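A few compounds are considered here, and "the series" means these few. Any claim that something is new, unique, unknown or untested is made for them only; others in the source may bear on it.

Measured so far in an in vitro functional assay on cells (Fibroblast) for agonist activity at Alpha-1A adrenergic receptor (Homo sapiens); a higher number here means that more compound is needed for the effect, a lower number that less compound is needed:
compound 1, `Cn1ncnc1-c1ccccc1NCC1=NCCN1`: in this assay compound 1 gives 2 nM
compound 2, `CCn1ncnc1-c1ccccc1NCC1=NCCN1`: in this assay compound 2 gives 1.26 nM
compound 3, `Cn1cccc1-c1ccccc1NCC1=NCCN1`: in this assay compound 3 gives 20 nM

Compound 4, `CCn1cccc1-c1ccccc1NCC1=NCCN1`, is not yet measured. It differs from compound 3 by methyl in place of hydrogen on a saturated chain carbon bound to an aromatic nitrogen. The same change has been made once before, from compound 1 to compound 2: methyl in place of hydrogen on a saturated chain carbon bound to an aromatic nitrogen, which gave a 1.6-fold lower number from compound 1 to compound 2 (0.20 log units; within the scatter). The two place descriptions read the same word for word, so this counts as the same change on a different core. The cores themselves differ as follows: 1-methyl-1H-pyrrol-2-yl in place of 1-methyl-1H-1,2,4-triazol-5-yl on an aromatic carbon, a difference that brought a 10-fold higher number from compound 1 to compound 3 (1.00 log units; beyond the scatter); compound 3 thus stands at the high end of the three numbers.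

Going by the values given here, the only precedent for the methyl-for-hydrogen change is a step within the scatter, so no real shift is expected for compound 4 either. Among the compounds with values here, the step from compound 3 to compound 4 is expected to be about a 1.4-fold lower number from compound 3 to compound 4 (0.15 log units; within the scatter), resting on the single earlier step of a 1.6-fold lower number from compound 1 to compound 2 (0.20 log units; within the scatter). Compound 4 is accordingly estimated at 14 nM in this assay, with the plausible range spanning 6 nM to 35 nM.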

Compound 4, half-maximal effective concentration: 2.51 nM
The estimate for compound 4 lay 5.6-fold (0.75 log units) above the measured number; measured number below the stated range.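

In this assay, methyl in place of hydrogen on a saturated chain carbon bound to an aromatic nitrogen gives an 8.0-fold lower number from compound 3 to compound 4 (0.90 log units; beyond the scatter). The size of this step did not carry over from one core to the other: the same change on two cores in this assay, a 1.6-fold lower number (0.20 log units; within the scatter) from compound 1 to compound 2 and an 8.0-fold lower number (0.90 log units; beyond the scatter) from compound 3 to compound 4, 5.0-fold (0.70 log units) apart, beyond the scatter of two such steps. This shows that the step seen on the core of compound 1 is a poor guide to its size on the core of compound 3, but two pairs give no general rule for the series and do not show what sets the size of the step.

On these data alone, whether a longer chain such as propyl, or a branched chain such as isopropyl, on the same aromatic nitrogen would widen or narrow the gap between the two cores remains open. Also open, as far as these compounds go, is how the step from methyl to ethyl would read on a third core, and whether a chain ending in a hydroxyl group or an amine would behave as ethyl does.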